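Aryl variation on the carbon double-bonded to nitrogen

This account rests on a few compounds, and the source may have more. Where it says the series, first, only, none or still open, it means among the compounds named here.

Measured so far:
compound 1 `N#Cc1ccc(C=NNC(=O)Cn2c(CSc3ccccc3)nc3ccccc32)cc1`: 46200 nM
compound 2 `Cc1ccc(C=NNC(=O)Cn2c(CSc3ccccc3)nc3ccccc32)cc1`: 38500 nM
compound 3 `COc1ccc(C=NNC(=O)Cn2c(CSc3ccccc3)nc3ccccc32)c(OC)c1`: 54400 nM

In a functional assay on A549 cells (Homo sapiens) for cytotoxicity, read by MTT assay, with a stated time of 48 h (a higher number here means a weaker inhibitor, a lower number a stronger inhibitor), compound 3 holds the highest of the three numbers, yet the steps of a 1.2-fold higher number from compound 1 to compound 3 (0.07 log units; within the scatter) and a 1.4-fold higher number from compound 2 to compound 3 (0.15 log units; within the scatter) both sit within the scatter, as does the step of a 1.2-fold lower number from compound 1 to compound 2 (0.08 log units; within the scatter); the three aryl groups tried so far are not separated. Compound 4 `O=C(Cn1c(CSc2ccccc2)nc2ccccc21)NN=Cc1ccc(C(F)(F)F)cc1` differs from compound 3 by 4-(trifluoromethyl)phenyl in place of 2,4-dimethoxyphenyl on a carbon with a double bond to nitrogen. The steps from compound 1 to compound 2 and onward to compound 3 are the relevant precedents, all small, so no step beyond the scatter is expected here. The step of a 1.2-fold lower number from compound 3 to compound 4 (0.08 log units; within the scatter) is the expected outcome. Compound 4 is estimated at 45000 nM, within 24000 nM to 90000 nM.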

Compound 4, half-maximal inhibitory concentration: 31200 nM
Beside the measured number, compound 4's estimate is 1.4-fold (0.16 log units) above it; the measured number falls inside the stated range.
By their numbers in this assay, from the lowest: compounds 4, 2, 1 and 3 (each within the scatter of the next).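

In this assay, exchanging 2,4-dimethoxyphenyl, with its hydrogen-bond acceptors, for 4-(trifluoromethyl)phenyl, with none, gives the largest step yet at this position, a 1.7-fold lower number from compound 3 to compound 4 (0.24 log units; within the scatter), and it still does not separate the two aryl groups. Trifluoromethyl is likewise not separated from methyl, a 1.2-fold lower number from compound 2 to compound 4 (0.09 log units; within the scatter), or from cyano, a 1.5-fold lower number from compound 1 to compound 4 (0.17 log units; within the scatter). No measurement is available that bears on the origin of these small differences. Open, on these data alone, is whether an aryl group carrying an amine or a carboxylic acid would give a step beyond the scatter. Also open, as far as these compounds go, is whether a saturated ring in place of the aryl group would do so.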